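A few compounds are considered here, and "the series" means these few. Any claim that something is new, unique, unknown or untested is made for them only; others in the source may bear on it.

In a functional assay on A549 cells (Homo sapiens) for cytotoxicity, read by MTT assay, with a stated time of 72 h (on this read-out higher numbers stand for weaker inhibition and lower numbers for stronger inhibition), compounds sharing one core have so far given an uneven picture. Compound 1 (`COc1ccc(/C=C/C(=O)Nc2cc3c(Nc4ccc(F)c(Cl)c4)ncnc3cc2O[C@H]2CCOC2)c(OC)c1`) gives 9350 nM. Among the compounds with values here, compound 2 (`N#Cc1ccc(/C=C/C(=O)Nc2cc3c(Nc4ccc(F)c(Cl)c4)ncnc3cc2O[C@H]2CCOC2)cc1`) is reported as "not active" (no number reported), so it has no single number, and no numerical step separates it from compound 1. Compound 3 (`O=C(/C=C/c1cc(Br)c(O)c(Br)c1)Nc1cc2c(Nc3ccc(F)c(Cl)c3)ncnc2cc1O[C@H]1CCOC1`) has not yet been measured in this assay. It differs from compound 2 by one exchange, with 3,5-dibromo-4-hydroxyphenyl in place of 4-cyanophenyl on a double-bonded chain carbon bound to a double-bonded chain carbon. Within the data shown here, no measured pair shows what this exchange does, so the size of the step cannot be read from the data. The expectation is a modest move toward stronger inhibition, from no reported number for compound 2 to a measurable but weak value in this assay. Among the measured compounds shown here, the only numerical anchor is compound 1 at 9350 nM, so a value in that general region is expected, although a result without a number remains possible. Compound 3 is estimated at 6000 nM, with an expected range from 1500 nM to 20000 nM.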

Compound 3, half-maximal inhibitory concentration: 28800 nM
Compound 3: the middle estimate sits 4.8-fold (0.68 log units) below what was measured; measured number above the stated range.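

In this assay, the place on a double-bonded chain carbon bound to a double-bonded chain carbon now gives its first numerical step: 3,5-dibromo-4-hydroxyphenyl in place of 2,4-dimethoxyphenyl produces a 3.1-fold higher number from compound 1 to compound 3 (0.49 log units; beyond the scatter) and so moves toward weaker inhibition. This shows that the shared core does not fix the read-out alone, and that changing the groups on this aromatic ring can shift it by more than the usual scatter. Compound 3 also has a number where compound 2 has none, but that step cannot be read, so the exchange of 4-cyanophenyl for 3,5-dibromo-4-hydroxyphenyl still has no size.

The compounds shown leave open which part of the 3,5-dibromo-4-hydroxyphenyl group goes with the change, the two bromine atoms or the hydroxyl, and what an aminophenyl or a carboxyphenyl group would give at this place. No supporting measurement bears on the reason for this step.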